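Swapping a 4-methylphenyl for ethynyl on a shared core

The source may report more compounds than this note shows. Statements on the series, on what has been measured and on what is new or still open speak of the compounds shown alone.

Three compounds were tested in a functional assay on KYSE-410 cells (Homo sapiens) for antiproliferative activity, read by MTT assay, with a stated time of 72 h; a higher number here means a weaker inhibitor, a lower number a stronger inhibitor. Compound 1 `COc1ccccc1NC(=O)c1ccnc2cc(Br)ccc12` gives > 20000 nM, which is a limit of the assay rather than a number. Compound 2 `O=C(Nc1cccc(F)c1)c1cc(=O)[nH]c2cc(F)ccc12` likewise gives > 20000 nM, again a limit. Compound 3 `Cc1ccc(-c2ccc3c(C(=O)Nc4cccc(F)c4)cc(=O)[nH]c3c2)cc1` gives > 20000 nM, also a limit. Because all three values sit at the limit of > 20000 nM in this assay, at which 3 of the 3 values shown sit, the step that the two limits leave unreadable from compound 2 to compound 3 cannot be read. Compound 4 `C#Cc1ccc2c(C(=O)Nc3cccc(F)c3)cc(=O)[nH]c2c1` differs from compound 3 by ethynyl in place of 4-methylphenyl on an aromatic carbon. For the measured compounds named here, every measured value is a limit, and no measured step therefore shows the size of such a change. Compound 4 is consequently expected to stay near the same limit, an expected step that the limit leaves unreadable from compound 3 to compound 4. The estimate for compound 4 in this assay is 30000 nM, within 8000 nM to 120000 nM.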

Compound 4, half-maximal inhibitory concentration: 9700 nM
Compound 4: middle estimate off by 3.1-fold (0.49 log units), on the high side; the range from low to high includes it.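

For the compounds shown here, compound 4 is the first compound here to give a value rather than a limit, so a change at this aromatic carbon can now be sized in this assay. Ethynyl in place of 4-methylphenyl gives an at least 2.0-fold lower number from compound 3 to compound 4 (0.31 log units; beyond the scatter), and ethynyl in place of fluoro gives an at least 2.0-fold lower number from compound 2 to compound 4 (0.31 log units; beyond the scatter). The step from fluoro to 4-methylphenyl still cannot be read, because compound 2 and compound 3 both sit at a limit: the limit of > 20000 nM in this assay, at which 3 of the 4 values shown sit.

Still open, as far as these compounds go, is whether another group on this carbon, such as an amine, a nitrile or a propyl chain, would lower the number further. Going by these compounds alone, with only one measured value, no trend across groups can be stated.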